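Ethyl on the chain carbon of compound 1

This account rests on a few compounds, and the source may have more. Where it says the series, first, only, none or still open, it means among the compounds named here.

In an ADME assay on MT4 cells (Homo sapiens) for cytotoxicity, read by MTT assay, with a stated time of 4 days (on this read-out higher numbers stand for lower toxicity in this test and lower numbers for higher toxicity in this test), compound 1 `CN(C)c1nc(Cc2c(F)cccc2F)cc(=O)[nH]1` gives > 94000 nM, which is a limit and not a number. Compound 2 `CC1CCCCN1c1nc(Cc2c(F)cccc2F)cc(=O)[nH]1` gives > 78000 nM, also a limit. Compound 3 `CN1CCN(c2nc(Cc3c(F)cccc3F)cc(=O)[nH]2)CC1` gives > 78000 nM, again a limit. Compound 1 therefore stands with no numerical value, and neither of the other two offers one for comparison.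

Compound 4 `CCC(c1cc(=O)[nH]c(N(C)C)n1)c1c(F)cccc1F` is not yet measured. It differs from compound 1 at one place: ethyl in place of hydrogen on a saturated chain carbon bound to two aromatic carbons. The ethyl sits on a saturated chain carbon bound to two aromatic carbons, and the rest of the structure stays as it is.

The measured steps bear on this only loosely, as both change the group on an aromatic carbon and neither touches the chain carbon. One is a step that the two limits leave unreadable from compound 1 to compound 2, with 2-methylpiperidin-1-yl in place of dimethylamino. The other is a step that the two limits leave unreadable from compound 1 to compound 3, with 4-methylpiperazin-1-yl in place of dimethylamino. Neither has a readable size, so no step beyond the scatter and no direction is expected in this assay.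

The expected step is an at least 1.1-fold lower number from compound 1 to compound 4 (0.04 log units; that floor lies within the scatter), and a limit is the likeliest report. For compound 4 the estimate is 85000 nM, with an expected range of 30000 nM to 120000 nM.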

Compound 4, half-maximal cytotoxic concentration: 73000 nM
Estimate against measurement, compound 4: 1.2-fold (0.07 log units) above; the measured number falls inside the stated range.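

In this assay, within the data shown here, ethyl on the saturated chain carbon bound to two aromatic carbons gives the only step with a readable floor, an at least 1.2-fold lower number from compound 1 to compound 4 (0.10 log units; that floor lies within the scatter), whereas the steps among the three earlier compounds, which all change the group on an aromatic carbon, cannot be read. This is also the only change shown at the chain carbon, and compound 4 is the only compound here with a number rather than a limit, so the series now has one value to compare later changes against. The step remains a floor rather than a size because compound 1 is held at a limit, so this result cannot show how far ethyl moves the read-out from hydrogen: the limit of > 94000 nM in this assay, at which 1 of the 4 values shown sits.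

The compounds shown carry only hydrogen and ethyl on this chain carbon, so it remains open how methyl, a longer chain such as propyl, a hydroxyl or a primary amine would read there. From the compounds shown here alone, it also remains open whether ethyl on this carbon would give a number alongside 2-methylpiperidin-1-yl or 4-methylpiperazin-1-yl in place of dimethylamino.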